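The source may report more compounds than this note shows. Statements on the series, on what has been measured and on what is new or still open speak of the compounds shown alone.

Compound 1 `Cc1ccc(C2CC(c3ccc4c(c3)OCCO4)=NN2c2ccccc2)cc1`: 2530 nM
Compound 2 `COc1ccc(C2CC(c3ccc4c(c3)OCCO4)=NN2c2ccccc2)cc1`: > 100000 nM

Both compounds were tested in a functional assay on WM 266-4 cells (Homo sapiens) for antiproliferative activity, read by MTT assay, with a stated time of 24 h; a higher number here means a weaker inhibitor of growth, a lower number a stronger inhibitor of growth. As far as these compounds go, compound 2 stands at > 100000 nM, which is a limit of the assay and not a number, so its true position is unknown. Compound 3 `c1ccc(C2CC(c3ccc4c(c3)OCCO4)=NN2c2ccccc2)cc1` has hydrogen in place of methoxy on an aromatic carbon, para to a large group: hydrogen in place of methoxy on an aromatic carbon. Among the measured compounds shown here, one measured step bears on this change: an at least 39-fold higher number from compound 1 to compound 2 (1.59 log units; beyond the scatter). That step is large and also involves the methoxy group, although it replaces methyl rather than hydrogen. Removing methoxy is therefore expected to give a large move towards a lower number in this assay, though with no direct measurement of hydrogen at this place. The expected change is an at least 16-fold lower number from compound 2 to compound 3 (1.22 log units; beyond the scatter). Compound 3 is estimated at 6000 nM, with an expected range from 1200 nM to 60000 nM.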

Compound 3, concentration for 50% growth inhibition: 22400 nM
Estimate against measurement, compound 3: 3.7-fold (0.57 log units) below; low and high end bracket the measured number.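

Compound 3 gives this position a reference with hydrogen, so methyl and methoxy can each be read against it in this assay. Replacing methyl with hydrogen weakens growth inhibition, with an 8.9-fold higher number from compound 1 to compound 3 (0.95 log units; beyond the scatter), whereas replacing methoxy with hydrogen strengthens it, with an at least 4.4-fold lower number from compound 2 to compound 3 (0.64 log units; beyond the scatter), so the two groups move the number in opposite directions from hydrogen. The methoxy step has a lower bound only, and its full size stays unknown, as compound 2 stands at a limit of the assay and not at a number: the limit of > 100000 nM in this assay, at which 1 of the 3 values shown sits.

The compounds shown leave open whether a larger alkyl group such as ethyl would keep the gain seen with methyl, and whether chlorine, hydroxyl or an amine would follow methyl or methoxy. They also leave open whether the same order holds with these groups elsewhere on this ring.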